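Ring stereocentre inversion in the phenol pair

A few compounds are considered here, and "the series" means these few. Any claim that something is new, unique, unknown or untested is made for them only; others in the source may bear on it.

Among the compounds with values here, compound 3 `CN1CCC[C@@H]1[C@H]1COc2ccc(O)cc2O1` gives the lowest number of the three measured so far in an assay on Cerebral cortex (strain Sprague-Dawley) for displacement of a labelled ligand from Neuronal acetylcholine receptor; alpha4/beta2 (Rattus norvegicus) (on this read-out higher numbers stand for weaker inhibition and lower numbers for stronger inhibition), at 3500 nM. Compound 2 `CN1CCC[C@H]1[C@H]1COc2ccc(CO)cc2O1` gives 9500 nM and compound 1 `CN1CCC[C@H]1[C@@H]1COc2ccc(CO)cc2O1` gives 51000 nM in this assay. Compound 4 `CN1CCC[C@@H]1[C@@H]1COc2ccc(O)cc2O1` is not yet measured. It differs from compound 3 only as follows: the two compounds have the same atoms and bonds and differ only in configuration as drawn: 1 of 2 stereo elements differ; a stereocentre at a saturated ring carbon is drawn S in compound 3 and R in compound 4.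

Within the data shown here, the one measured step of the same kind is the pair of hydroxymethyl compounds, where a 5.4-fold lower number from compound 1 to compound 2 (0.73 log units; beyond the scatter). That step rests on (the fact that compounds 1 and 2 differ only in the configuration as drawn), a change at the same saturated ring carbon as the present one, and the relative configuration of the two ring carbons in compound 4 matches that in compound 2, as that in compound 3 matches compound 1. A step in the same direction is therefore expected, though the absolute configuration at the other centre is inverted in the phenol pair, and the phenol carries a different substituent, so the size is taken with caution.

Compound 4 is expected to give 1000 nM in this assay, with a range of 250 nM to 4000 nM, which means an expected step of a 3.5-fold lower number from compound 3 to compound 4 (0.54 log units; beyond the scatter).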

Compound 4, inhibition constant: 3000 nM
For compound 4 the middle estimate is 3.0-fold (0.48 log units) below the measured one, and the stated range covers the measured number.
By their numbers in this assay, from the lowest: compounds 4 and 3 (each within the scatter of the next); then compound 2; then compound 1.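

In the phenol pair, inverting this saturated ring carbon leaves the read-out in this assay within the scatter, with a 1.2-fold lower number from compound 3 to compound 4 (0.07 log units; within the scatter). The hydroxymethyl pair had shown a 5.4-fold lower number from compound 1 to compound 2 (0.73 log units; beyond the scatter) for a change at the same carbon, so the dependence on configuration seen there does not carry over to the phenol pair. The comparison is a clean one, with no atom or bond altered: the fact that compounds 3 and 4 differ only in the configuration as drawn

The two pairs differ both in the ring substituent and in the drawn configuration at the other stereocentre, and the compounds shown do not separate these two differences. As far as these compounds go, whether this inversion also stays within the scatter with an amine or a carboxylic acid in place of the hydroxyl remains open.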